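The compounds below may be only part of what the source reports. "The series", "measured", "known", "first", "only" and "open" are said of these compounds alone.

Measured compounds in a functional assay on PC-3 cells (Homo sapiens) for cytotoxicity, read by sulforhodamine B assay; on this read-out higher numbers stand for lower toxicity in this test and lower numbers for higher toxicity in this test:
compound 1, `COc1cccc(OC)c1OCCNCCOc1ccccc1OCc1ccccc1`, compound 1 gives 193000 nM
compound 2, `COc1cccc(OC)c1OCCNCCOc1ccccc1OCc1ccccc1Cl`, compound 2 gives 58900 nM
compound 3, `COc1cccc(OC)c1OCCNCCOc1ccccc1OCc1ccc(Cl)cc1`, compound 3 gives 52500 nM

Compound 3 holds the lowest number of the three in this assay, though its nearest neighbour, compound 2, sits within the scatter of it, so the two cannot be ranked against each other; only compound 1 stands clearly apart, as a 3.7-fold lower number from compound 1 to compound 3 (0.57 log units; beyond the scatter) shows.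

Compound 4 is `COc1cccc(OC)c1OCCNCCOc1ccccc1OCc1cccc(C)c1`. Its difference from compound 3 is 3-methylphenyl in place of 4-chlorophenyl on a saturated chain carbon bound to an oxygen on an aromatic ring. For the measured compounds named here, no measured step swaps a chloro for a methyl on this ring, so the nearest guides are the two chloro additions, a 3.3-fold lower number from compound 1 to compound 2 (0.52 log units; beyond the scatter) and a 3.7-fold lower number from compound 1 to compound 3 (0.57 log units; beyond the scatter), both modest and both beyond the scatter, while a 1.1-fold lower number from compound 2 to compound 3 (0.05 log units; within the scatter) shows that moving the chloro around the ring changed little. Because a 3.7-fold lower number from compound 1 to compound 3 (0.57 log units; beyond the scatter) marks the chloro as the source of the lower number of compound 3, removing it is expected to give back part of that step, and compound 4 is expected to land between compound 1 and compound 3, with a 1.5-fold higher number from compound 3 to compound 4 (0.18 log units; within the scatter) as the estimated step. Compound 4 is therefore estimated at 80000 nM, within 35000 nM to 180000 nM.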

Compound 4, concentration lethal to 50% of the cells: 87100 nM
Compound 4: middle estimate off by 1.1-fold (0.04 log units), on the low side, within the range that was stated.
By their numbers in this assay, from the lowest: compounds 3, 2 and 4 (each within the scatter of the next); then compound 1.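

In this assay, compound 4 shows that the step away from compound 1 does not need a chloro, since a methyl instead also gives a modest shift beyond the scatter (a 2.2-fold lower number from compound 1 to compound 4 (0.35 log units; beyond the scatter)). At this site on a saturated chain carbon bound to an oxygen on an aromatic ring, the assay does not separate 3-methylphenyl from either chlorophenyl group: both comparisons stay within the scatter (a 1.7-fold higher number from compound 3 to compound 4 (0.22 log units; within the scatter); a 1.5-fold higher number from compound 2 to compound 4 (0.17 log units; within the scatter)), so compounds 2, 3 and 4 read as one group, with compound 1 alone standing clearly apart from all of them. Nothing given here accounts for this shared shift, and no measurement on the groups themselves bears on it.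

From the compounds shown here alone, both steps to compound 4 change the kind of group and its place on the ring together, so the part played by each stays open. Also open, going by these compounds, is whether a methoxy, a nitrile or a carboxylic acid on this ring, or a longer chain joining this ring to the oxygen, would move the number clearly beyond that of compound 3.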